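Working notes: from compound 1 to compound 4

A few compounds are considered here, and "the series" means these few. Any claim that something is new, unique, unknown or untested is made for them only; others in the source may bear on it.

Measured in a functional assay on K562 cells (Homo sapiens) for inhibition, read by MTT assay, with a stated time of 48 h; a lower number here means a stronger inhibitor, a higher number a weaker inhibitor:
- compound 1 `CC(C)(C)OC(=O)N1C[C@@H](n2cc(-c3ccc4c(N)n[nH]c4c3)nn2)C[C@H]1C(=O)Nc1ccc(Cl)cc1Cl`: 12200 nM
- compound 2 `CC(C)(C)OC(=O)N1C[C@@H](n2cc(-c3ccc4c(N)n[nH]c4c3)nn2)C[C@H]1C(=O)Nc1ccc(Br)cc1`: 3710 nM
- compound 3 `Nc1n[nH]c2cc(-c3cn([C@@H]4CN[C@H](C(=O)Nc5ccc(Cl)cc5Cl)C4)nn3)ccc12`: 28400 nM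

Compound 1 sits in the middle of these three numbers, with compound 3 higher and compound 2 lower. Compound 4 `CC(C)(C)OC(=O)N1C[C@@H](n2cc(-c3ccc4nc(N)sc4n3)nn2)C[C@H]1C(=O)Nc1ccc(Cl)cc1Cl` keeps the rest of compound 1 and differs on an aromatic carbon of the five-membered aromatic ring with 3 nitrogen: a group of 10 heavy atoms (6 carbon, 3 nitrogen, 1 sulfur; one five-membered aromatic ring with 2 hetero atoms, one six-membered aromatic ring with 1 hetero atom) in place of a group of 10 heavy atoms (7 carbon, 3 nitrogen; one five-membered aromatic ring with 2 hetero atoms, one six-membered aromatic ring of carbon only), on an aromatic carbon. For the measured compounds named here, no measured step touches this place. The nearest guides, made at other places, are a 3.3-fold lower number from compound 1 to compound 2 (0.52 log units; beyond the scatter) and a 2.3-fold higher number from compound 1 to compound 3 (0.37 log units; beyond the scatter). Both are modest and give a size only, not a direction, for this assay. The estimated step is a 1.1-fold higher number from compound 1 to compound 4 (0.06 log units; within the scatter). For compound 4 the estimated value is 14000 nM, with an expected range of 5000 nM to 40000 nM.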

Compound 4, half-maximal inhibitory concentration: 8940 nM
For compound 4 the middle estimate is 1.6-fold (0.19 log units) above the measured one; low and high end bracket the measured number.
By their numbers in this assay, from the lowest: compound 2; then compounds 4 and 1 (each within the scatter of the next); then compound 3.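

In this assay, for the compounds shown here, the step is a 1.4-fold lower number from compound 1 to compound 4 (0.14 log units; within the scatter) and gives the only reading at this aromatic carbon of the five-membered aromatic ring with 3 nitrogen. The 3-amino-1H-indazol-6-yl group can thus give way to a sulfur-bearing group of equal heavy-atom count, with different hydrogen-bond donor and acceptor counts, and the number stays within the scatter. No measurement here explains this result.

As far as these compounds go, whether this exchange reads the same with the 4-bromophenyl of compound 2 or the free ring amine of compound 3 stays open. So does the effect of a carboxylic acid or a plain phenyl group at this carbon.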